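A few compounds are considered here, and "the series" means these few. Any claim that something is new, unique, unknown or untested is made for them only; others in the source may bear on it.

Series notes, cytotoxicity arm. Compound 1 `C[C@]1(CN2CCc3nc(-c4ccccc4)ncc3C2)Cn2cc([N+](=O)[O-])nc2O1` in an ADME assay on Vero cells (Chlorocebus sabaeus) for cytotoxicity, read by MTT assay, with a stated time of 72 h (a lower number here means that less compound is tolerated, a higher number that more compound is tolerated), gives "not determined" (no result reported). Compound 2 `C[C@]1(CN2CCc3nc(-c4ccc(F)cc4)sc3C2)Cn2cc([N+](=O)[O-])nc2O1` in this assay gives > 32 ug/mL, which is a limit of the assay and not a number. Compound 3 `C[C@]1(CN2CCc3nc(-c4ccc(C#N)cc4)ccc3C2)Cn2cc([N+](=O)[O-])nc2O1` in this assay gives "not determined" (no result reported), so compound 3 stands without a number of its own. Among its companions, compound 2 sits at the limit of > 32 ug/mL in this assay, at which 1 of the 3 values shown sits, and compound 1 is without result. Compound 4 `C[C@]1(CN2CCc3nc(-c4cc(F)cc(Cl)c4)ccc3C2)Cn2cc([N+](=O)[O-])nc2O1` is not yet measured. It differs from compound 3 by 3-chloro-5-fluorophenyl in place of 4-cyanophenyl on an aromatic carbon. Within the data shown here, with no measured step in the set, no change beyond the scatter is expected in this assay from this change. For compound 4 the half-maximal cytotoxic concentration is estimated at 32 ug/mL, between 16 ug/mL and 64 ug/mL, likely reported again only as a limit.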

Compound 4, half-maximal cytotoxic concentration: > 32 ug/mL
Compound 4 ended at the assay's limit; the forecaster's own chance of this, stated with the estimate: 70%; the middle value lies on the limit itself.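

No step can be read between compound 3 and compound 4: compound 3 has no number, and in this assay compound 4 gives > 32 ug/mL, a limit of the assay. The compounds shown leave open whether changing this aromatic group shifts the half-maximal cytotoxic concentration at all.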